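Returning an aromatic ring to the double-bonded nitrogen

The compounds below may be only part of what the source reports. "The series", "measured", "known", "first", "only" and "open" are said of these compounds alone.

Of the compounds shown here, three sharing one core have been measured in a functional assay on NCI-H23 cells (Homo sapiens) for antiproliferative activity, read by sulforhodamine B assay; on this read-out lower numbers stand for stronger inhibition of growth and higher numbers for weaker inhibition of growth. Compound 1 `CC(C)C1CC(=O)c2s/c(=N/c3ccccc3)oc2C1` gives 2280 nM. Compound 2 `CC(C)C1CC(=O)c2s/c(=N/C3CCCCC3)oc2C1` carries a cyclohexyl where compound 1 carries a phenyl; in this assay compound 2 gives 7080 nM. Compound 3 `CC1CC(=O)c2s/c(=N/c3ccc(Cl)cc3)oc2C1`, which is not a single-step neighbour of either of them, gives 13500 nM. Among these three numbers compound 2 stands second highest: its value and that of compound 3 lie within the usual scatter of each other, while the step from compound 1 to compound 2 is a 3.1-fold higher number from compound 1 to compound 2 (0.49 log units; beyond the scatter), which is beyond the scatter and so counts as a modest but genuine weakening of growth inhibition.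

Compound 4 `CC(C)C1CC(=O)c2s/c(=N/c3ccc(F)cc3)oc2C1` has not yet been measured. It differs from compound 2 by 4-fluorophenyl in place of cyclohexyl on a double-bonded nitrogen. Among the measured compounds shown here, this change largely reverses the one measured step that bears on it: an aromatic ring returns in place of the non-aromatic one, now carrying a fluorine. On that basis a step back toward the number of compound 1 is expected, in the direction of stronger inhibition and of roughly the size seen before. Compound 4 is therefore estimated at 2500 nM, with a plausible range from 1000 nM to 7000 nM, meaning an expected step of a 2.8-fold lower number from compound 2 to compound 4 (0.45 log units; beyond the scatter). For the measured compounds named here, compound 3, with a halogen on its aromatic ring but a different group on the core, offers no separate step against which to check this.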

Compound 4, concentration for 50% growth inhibition: 3650 nM
For compound 4 the middle estimate is 1.5-fold (0.16 log units) below the measured one; measured number inside the range.
By their numbers in this assay, from the lowest: compounds 1, 4, 2 and 3 (each within the scatter of the next, the first and the last beyond it).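

In this assay, putting 4-fluorophenyl in place of cyclohexyl on the double-bonded nitrogen gives a 1.9-fold lower number from compound 2 to compound 4 (0.29 log units; within the scatter), so this swap cannot be told apart from the ordinary variation between repeated measurements, although the unsubstituted phenyl of compound 1 did stand clear of cyclohexyl. Placing fluoro on that aromatic ring gives a 1.6-fold higher number from compound 1 to compound 4 (0.20 log units; within the scatter), so this small change also makes no readable difference, and the only evidence that an aromatic ring on this nitrogen outperforms cyclohexyl remains the single comparison between compound 1 and compound 2. No independent data are available to explain these results.

From the compounds shown here alone, it remains open whether a different group on the aromatic ring, such as methoxy, a nitrile or an amine, would separate clearly from compound 1 in either direction. Also open, going by these compounds, is whether an open chain on the nitrogen, such as a butyl group, would match cyclohexyl or the aromatic rings, or differ from both.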